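A few compounds are considered here, and "the series" means these few. Any claim that something is new, unique, unknown or untested is made for them only; others in the source may bear on it.

Measured in a functional assay on UACC-62 cells (Homo sapiens) for cytotoxicity, read by sulforhodamine B assay; a higher number here means that more compound is tolerated, a lower number that less compound is tolerated:
compound 1 `CC1=CC[C@@H]([C@@](C)(O)CCCC(C)(C)NC(=S)N/N=C\c2ccccc2)CC1` gives 48400 nM
compound 2 `CC1=CC[C@@H]([C@@](C)(O)CCCC(C)(C)NC(=S)N/N=C\c2ccc(O)cc2)CC1` gives 55600 nM
compound 3 `CC1=CC[C@@H]([C@@](C)(O)CCCC(C)(C)NC(=S)N/N=C\c2ccccc2[N+](=O)[O-])CC1` gives 49300 nM

Compound 3 takes no separable place among the three values. The steps that reach it (a 1.0-fold higher number from compound 1 to compound 3 (0.01 log units; within the scatter) and a 1.1-fold lower number from compound 2 to compound 3 (0.05 log units; within the scatter)) lie within the scatter, as does the remaining step (a 1.1-fold higher number from compound 1 to compound 2 (0.06 log units; within the scatter)).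

Compound 4 `CC1=CC[C@@H]([C@@](C)(O)CCCC(C)(C)NC(=S)N/N=C\c2ccc([N+](=O)[O-])cc2)CC1` is the next case, with this change: 4-nitrophenyl in place of 2-nitrophenyl on a carbon with a double bond to nitrogen. Among the compounds with values here, no measured step moves the nitro group itself, so the evidence is indirect. Each aromatic change so far has stayed within the scatter, so no step beyond it is expected in this assay. The expected step is small (a 1.0-fold higher number from compound 3 to compound 4 (0.01 log units; within the scatter)). Compound 4 is estimated at 50000 nM (expected range 30000 nM to 80000 nM).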

Compound 4, concentration lethal to 50% of the cells: > 100000 nM
Compound 4 was reported as a limit; the forecaster's own chance of this, stated with the estimate: 3%; at least 2.0-fold (0.30 log units) between middle value and limit.
By their numbers in this assay, from the lowest: compounds 1, 3 and 2 (each within the scatter of the next). At a limit, above all of these: compound 4.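

In this assay compound 4 gives > 100000 nM as a limit of the assay, not a number: the limit of > 100000 nM in this assay, at which 1 of the 4 values shown sits.
Moving the nitro group gives an at least 2.0-fold higher number from compound 3 to compound 4 (0.30 log units; that floor lies within the scatter) and an at least 1.7-fold higher number from compound 2 to compound 4 (0.25 log units; that floor lies within the scatter) also has its floor within the scatter, while an at least 2.0-fold higher number from compound 1 to compound 4 (0.31 log units; beyond the scatter) is the only step in the series beyond it. Within the data shown here, this is the first sign that the place of the nitro group can count, since compound 3 shows no separable step from compound 1.

As far as these compounds go, the true value of compound 4 remains unknown, so the full size of its steps cannot be read. From the compounds shown here alone, whether an amine or a carboxylic acid on the phenyl ring would behave like the nitro group of compound 4 remains open.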